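Amide variations on a flavonol series: next compound

The source may hold more compounds than are shown below. What is called first, only, known or untested is meant among the compounds shown, and "the series" means these compounds.

Measured so far:
- compound 1 `COc1ccc(C(=O)Nc2cccc(-c3oc4cc(-c5ccc(F)cc5)ccc4c(=O)c3O)c2)cc1`: 6250 nM
- compound 2 `Cc1ccccc1C(=O)Nc1cccc(-c2oc3cc(-c4ccc(F)cc4)ccc3c(=O)c2O)c1`: 2280 nM
- compound 3 `O=C(Nc1cccc(-c2oc3cc(-c4ccc(F)cc4)ccc3c(=O)c2O)c1)c1cccc(F)c1`: 5770 nM

In a functional assay on MCF7 cells (Homo sapiens) for antiproliferative activity, read by CCK-8 assay, with a stated time of 72 h (on this read-out lower numbers stand for stronger inhibition and higher numbers for weaker inhibition), compound 3 stands second highest of the three numbers; its nearest neighbour is compound 1, a 1.1-fold lower number from compound 1 to compound 3 (0.03 log units; within the scatter), and its furthest is compound 2, a 2.5-fold higher number from compound 2 to compound 3 (0.40 log units; beyond the scatter). Compound 4 `COc1ccc(C(=O)Nc2cccc(-c3oc4cc(-c5ccc(F)cc5)ccc4c(=O)c3O)c2)c(F)c1` differs from compound 3 by 2-fluoro-4-methoxyphenyl in place of 3-fluorophenyl on a carbonyl carbon. Within the data shown here, two measured steps bear on this: the 4-methoxyphenyl of compound 1 sits within the scatter of compound 3, a 1.1-fold lower number from compound 1 to compound 3 (0.03 log units; within the scatter), whereas the 2-methylphenyl of compound 2 gave a 2.7-fold lower number from compound 1 to compound 2 (0.44 log units; beyond the scatter). Compound 4 combines a 4-methoxy group with a 2-fluoro group, so in this assay a small step downward is expected, a 1.4-fold lower number from compound 3 to compound 4 (0.16 log units; within the scatter), not clearly beyond the scatter. Compound 4 is estimated at 4000 nM, ranging from 1500 nM to 10000 nM.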

Compound 4, half-maximal inhibitory concentration: 20000 nM
Compound 4: middle estimate off by 5.0-fold (0.70 log units), on the low side; measured number above the stated range.
By their numbers in this assay, from the lowest: compound 2; then compounds 3 and 1 (each within the scatter of the next); then compound 4.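

In this assay, fluoro in place of hydrogen on an aromatic carbon of the 4-methoxyphenyl group weakens compound 1 (a 3.2-fold higher number from compound 1 to compound 4 (0.51 log units; beyond the scatter)), so this ring is not indifferent to one added fluoro. The 2-fluoro-4-methoxyphenyl group on the carbonyl carbon also trails 3-fluorophenyl (a 3.5-fold higher number from compound 3 to compound 4 (0.54 log units; beyond the scatter)) and 2-methylphenyl (an 8.8-fold higher number from compound 2 to compound 4 (0.94 log units; beyond the scatter)), widening the spread seen at this place. No measurement shown explains the loss. Open, as far as these compounds go, is whether the same fluoro would weaken compounds carrying other groups on this ring. Also open, from the compounds shown here alone, is how an amine or a carboxylic acid would fare in place of the methoxy group.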